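The source may report more compounds than this note shows. Statements on the series, on what has been measured and on what is new or still open speak of the compounds shown alone.

Measured compounds in a functional assay on A549 cells (Homo sapiens) for cytotoxicity, with a stated time of 48 h; a higher number here means a weaker inhibitor, a lower number a stronger inhibitor:
- compound 1, `CC(=O)Oc1ccc2oc(/C=C/[S+](C)[O-])cc(=O)c2c1`: 4100 nM
- compound 2, `C[S+]([O-])/C=C/c1cc(=O)c2ccccc2o1`: 1900 nM
- compound 3, `CC(C)Oc1ccc2oc(/C=C/[S+](C)[O-])cc(=O)c2c1`: 1500 nM

Among these three numbers compound 2 stands second highest; compound 3 sits closest, and the gap between them, a 1.3-fold lower number from compound 2 to compound 3 (0.10 log units; within the scatter), is within the scatter. Compound 1 lies furthest away, the step of a 2.2-fold lower number from compound 1 to compound 2 (0.33 log units; beyond the scatter) being beyond the scatter.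

The unmeasured compound 4, `C[S+]([O-])/C=C/c1cc(=O)c2cc(OC(=O)C(C)(C)C)ccc2o1`, differs from compound 2 in one place: ((tert-butyl)carbonyl)oxy in place of hydrogen on an aromatic carbon

Going by the values given here, two measured steps bear on this change. The step of a 2.2-fold lower number from compound 1 to compound 2 (0.33 log units; beyond the scatter) shows that removing an acetoxy group from the same aromatic carbon lowered the number modestly, so putting an ester back at that position would be expected to raise it by a similar amount. The step of a 2.7-fold lower number from compound 1 to compound 3 (0.44 log units; beyond the scatter) shows that an isopropyl in place of acetyl on that oxygen lowered the number modestly, while the step of a 1.3-fold lower number from compound 2 to compound 3 (0.10 log units; within the scatter) stayed within the scatter. The group entering compound 4 is an ester like that of compound 1, not an ether like that of compound 3, so a modest rise in the number in this assay is expected, of size a 1.7-fold higher number from compound 2 to compound 4 (0.23 log units; within the scatter). Compound 4 is therefore estimated at 3200 nM, with a likely range from 1500 nM to 7000 nM.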

Compound 4, half-maximal inhibitory concentration: 1600 nM
The estimate for compound 4 lay 2.0-fold (0.30 log units) above the measured number; the measured number falls inside the stated range.
By their numbers in this assay, from the lowest: compounds 3, 4 and 2 (each within the scatter of the next); then compound 1.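

In this assay the ((tert-butyl)carbonyl)oxy group on this aromatic carbon gives a number that cannot be told apart from that of hydrogen (a 1.2-fold lower number from compound 2 to compound 4 (0.07 log units; within the scatter)), so an ester at this position does not in itself bring the rise that compound 1 had suggested. The number also cannot be told apart from that of the isopropoxy ether (a 1.1-fold higher number from compound 3 to compound 4 (0.03 log units; within the scatter)), which means the gap between compound 1 and compound 3 cannot be read as a general gap between esters and ethers on this oxygen. Swapping methyl for tert-butyl on the carbonyl carbon is a change at a single place, and it produces a real step (a 2.6-fold lower number from compound 1 to compound 4 (0.41 log units; beyond the scatter)), leaving compound 1 alone apart from the other three, whose numbers all lie within the scatter of one another.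

The compounds shown leave open whether an ethyl or a phenyl on that carbonyl carbon would side with compound 1 or with compound 4, and how an amine or a carboxylic acid on this aromatic carbon would compare. No measurement is at hand that explains the step between the two esters.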